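From fluoro to bromo: a small swap at a limit

The source may report more compounds than this note shows. Statements on the series, on what has been measured and on what is new or still open speak of the compounds shown alone.

Compound 1 `CC(=O)Nc1ccc2oc(-c3ccnc(C(=O)N4CCN(C(c5nnn(C)n5)c5ccccc5F)CC4)c3)nc2c1`: > 50000 nM, a limit
Compound 2 `CC(=O)Nc1ccc2oc(-c3ccnc(C(=O)N4CCN(C(c5ccc(F)cc5)c5nnn(C)n5)CC4)c3)nc2c1`: > 50000 nM, a limit
Compound 3 `CC(=O)Nc1ccc2oc(-c3ccnc(C(=O)N4CCN([C@@H](c5ccc(F)cc5)c5nnn(C)n5)CC4)c3)nc2c1`: > 200000 nM, a limit
Compound 4 `CC(=O)Nc1ccc2oc(-c3ccnc(C(=O)N4CCN(C(c5ccc(Br)cc5)c5nnn(C)n5)CC4)c3)nc2c1`: not yet measured

In an ADME assay on MDCK cells (Canis lupus familiaris) for cytotoxicity (a lower number here means that less compound is tolerated, a higher number that more compound is tolerated), compound 2 gives > 50000 nM, which is a limit and not a number. Compound 4 differs from compound 2 in a single place: bromo in place of fluoro on an aromatic carbon. In words, this is bromo in place of fluoro on an aromatic carbon, para to a large group.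

For the measured compounds named here, two measured steps bear on this only loosely. The first, a step that the two limits leave unreadable from compound 1 to compound 2, puts 4-fluorophenyl in place of 2-fluorophenyl. The second, a step that the two limits leave unreadable from compound 2 to compound 3, only defines the configuration at one stereocentre. Neither replaces fluoro with bromo, and neither has a size that can be read.

With the limit of compound 2 at > 50000 nM, no step beyond the scatter is expected in this assay, and no direction can be named. The expected change is a step that the limit leaves unreadable from compound 2 to compound 4. For compound 4 the estimate is 70000 nM, with an expected range from 30000 nM to 200000 nM, and the assay will probably report only a limit.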

Compound 4, half-maximal cytotoxic concentration: > 50000 nM
Compound 4 ended at the assay's limit; the forecaster's own chance of this, stated with the estimate: 80%; the middle value lies beyond the limit too.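

In this assay compound 4 gives > 50000 nM, a limit and not a number. The steps to compound 4 from compound 1 and from compound 2 cannot be read, since those compounds also sit at limits. From the compounds shown here alone, whether bromo in place of fluoro changes how much compound the cells tolerate stays open.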